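From Ethoxycarbonyl to Isopropoxycarbonyl

The source may hold more compounds than are shown below. What is called first, only, known or untested is meant among the compounds shown, and "the series" means these compounds.

In a functional assay (aorta) for inhibition, with Oryctolagus cuniculus as the target (a higher number here means a weaker inhibitor, a lower number a stronger inhibitor), compound 1 `CCOC(=O)N1C(=S)N=C(C)/C(=C(/O)OCC)C1c1cccc([N+](=O)[O-])c1` gives 17 nM and compound 3 `CCOC(=O)N1C(=S)N=C(C)/C(=C(/O)OCC)C1c1ccccc1C(F)(F)F` gives 41 nM. Compound 2 `CCOC(=O)C1=C(C)N=C(S)NC1c1cccc([N+](=O)[O-])c1` gives only a limit of the assay, > 1000 nM, and not a number. Compound 3 therefore has the higher of the two true numbers, and its gap to compound 1 lies beyond the usual scatter, making it the weaker inhibitor of that pair.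

Compound 4 `CCO/C(O)=C1\C(C)=NC(=S)N(C(=O)OC(C)C)C1c1ccccc1C(F)(F)F` differs from compound 3 in one place: methyl in place of hydrogen on a saturated chain carbon bound to an oxygen next to a carbonyl group and a saturated chain carbon. This is methyl in place of hydrogen on a saturated chain carbon bound to an oxygen next to a carbonyl group and a saturated chain carbon, so ethoxycarbonyl becomes isopropoxycarbonyl. Among the compounds with values here, no measured pair here shows this change on its own, so the expectation stays close to compound 3 at 41 nM. In this assay the expected result is a 1.2-fold lower number from compound 3 to compound 4 (0.07 log units; within the scatter), a step not expected to go beyond the scatter. For compound 4 the estimated value is 35 nM, with a range from 12 nM to 110 nM.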

Compound 4, half-maximal inhibitory concentration: 50 nM
For compound 4 the middle estimate is 1.4-fold (0.15 log units) below the measured one, and the stated range covers the measured number.
By their numbers in this assay, from the lowest: compound 1; then compounds 3 and 4 (each within the scatter of the next). At a limit, above all of these: compound 2.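

In this assay, within the data shown here, the change from ethoxycarbonyl to isopropoxycarbonyl gives a 1.2-fold higher number from compound 3 to compound 4 (0.09 log units; within the scatter), the first reading of this change on its own. At this place, on a saturated chain carbon bound to an oxygen next to a carbonyl group and a saturated chain carbon, an added methyl leaves the two compounds indistinguishable in this test, so the branched chain is as compatible with the result as the straight ethyl. No measurement shown here offers an explanation of this result.

Still open, on these data alone, is whether a larger group, such as tert-butyl, or a longer chain, such as butyl, or a chain ending in an amine would hold the value at this place. Also open, as far as these compounds go, is whether isopropoxycarbonyl would behave the same on the core of compound 1.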